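Working notes: from compound 2 to compound 3

A few compounds are considered here, and "the series" means these few. Any claim that something is new, unique, unknown or untested is made for them only; others in the source may bear on it.

- compound 1 `CNC(=O)c1ccc(Oc2ccc3c(C)c(C(=O)OC(C)C)sc3c2)cn1`: 7600 nM
- compound 2 `CNC(=O)c1cc(Oc2ccc3ccc(C(=O)OC)cc3c2)ccn1`: 53500 nM

In an ADME assay on H1-HeLa cells (Homo sapiens) for cytotoxicity, read by MTT assay, with a stated time of 3 days (on this read-out higher numbers stand for lower toxicity in this test and lower numbers for higher toxicity in this test), compound 2 holds the higher of the two numbers at 53500 nM, and compound 1 lies lower at 7600 nM, a gap beyond the usual scatter. These two compounds differ in more than one place, so the gap cannot be tied to any single structural feature.

The next compound is compound 3 `CCC(C)OC(=O)c1ccc2ccc(Oc3ccnc(C(=O)NC)c3)cc2c1`, which differs from compound 2 by one change: sec-butyl in place of methyl on an oxygen next to a carbonyl group. This places sec-butyl in place of methyl on an oxygen next to a carbonyl group, turning methoxycarbonyl into sec-butoxycarbonyl.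

Within the data shown here, no single-change pair among the measured compounds calibrates this step. Among the measured compounds shown here, the only guide is that compound 1 at 7600 nM sits lower, so a moderate downward move in this assay is expected, though this remains weakly supported. The expected size of the change is a 2.4-fold lower number from compound 2 to compound 3 (0.39 log units; beyond the scatter). For compound 3 the estimated value is 22000 nM, with an expected range of 7000 nM to 65000 nM.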

Compound 3, half-maximal cytotoxic concentration: 16000 nM
Beside the measured number, compound 3's estimate is 1.4-fold (0.14 log units) above it; low and high end bracket the measured number.
By their numbers in this assay, from the lowest: compound 1; then compound 3; then compound 2.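

In this assay the change from methoxycarbonyl to sec-butoxycarbonyl gives a 3.3-fold lower number from compound 2 to compound 3 (0.52 log units; beyond the scatter) and thus points towards higher toxicity in this test. Among these compounds, this is the first pair that differs in one place only, and it shows that the group on this oxygen can by itself shift the number beyond the usual scatter, which the gap between compound 1 and compound 2 could not show, as those two differ in more than one place. Nothing available here bears on what lies behind this step.

As far as these compounds go, with only methyl and sec-butyl compared on this oxygen on the core of compound 2, a single step sets no trend, and it remains open whether the number keeps falling with a larger group, or whether branching matters, which an ethyl group, a straight butyl chain or the free carboxylic acid would help to settle. From the compounds shown here alone, it also remains open whether the same change would move the number by a similar amount on the core of compound 1, which carries a different core and a different group on the matching oxygen.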